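This account rests on a few compounds, and the source may have more. Where it says the series, first, only, none or still open, it means among the compounds named here.

In a functional assay on A549 cells (Homo sapiens) for inhibition, read by MTT assay, with a stated time of 24 h (a lower number here means a stronger inhibitor of growth, a higher number a weaker inhibitor of growth), compound 1 (`COc1ccc2c(c1)c(-c1nc3ccccc3n1C(=O)c1ccccc1OC)cn2C`) gives 11900 nM, and compound 2 (`COc1cccc(C(=O)n2c(-c3cn(C)c4ccc(OC)cc34)nc3ccccc32)c1`) gives 4600 nM. Among the measured compounds shown here, compound 2 therefore has the lower of the two numbers measured so far, making it the stronger inhibitor of growth of this pair. Compound 3 (`COc1ccc(C(=O)n2c(-c3cn(C)c4ccc(OC)cc34)nc3ccccc32)cc1`) keeps the shared core and differs from compound 2 in one place: 4-methoxyphenyl in place of 3-methoxyphenyl on a carbonyl carbon. In words, 4-methoxyphenyl stands in place of 3-methoxyphenyl on a carbonyl carbon.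

For the measured compounds named here, only one measured step bears on this change: a 2.6-fold lower number from compound 1 to compound 2 (0.41 log units; beyond the scatter). That modest step, beyond the scatter, came with 3-methoxyphenyl in place of 2-methoxyphenyl on a carbonyl carbon. It suggests that a similar exchange can shift the number in this assay, but a single step does not show which way the next exchange will go. Going by the values given here, no measured compound yet carries 4-methoxyphenyl, so no clear direction can be expected, and the best single guess is no change beyond the scatter. The estimated step is a 1.1-fold higher number from compound 2 to compound 3 (0.04 log units; within the scatter). Compound 3 is expected to give about 5000 nM, with an estimated range from 1800 nM to 13000 nM.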

Compound 3, concentration for 50% growth inhibition: 4900 nM
Beside the measured number, compound 3's estimate is 1.0-fold (0.01 log units) above it; measured number inside the range.
By their numbers in this assay, from the lowest: compounds 2 and 3 (each within the scatter of the next); then compound 1.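

In this assay, 4-methoxyphenyl and 3-methoxyphenyl on this carbonyl carbon cannot be told apart, with a 1.1-fold higher number from compound 2 to compound 3 (0.03 log units; within the scatter) as the measured step between them. Compound 1, with its 2-methoxyphenyl group, now stands apart from both of the others, as the weakest inhibitor of growth of the three, shown by a 2.4-fold lower number from compound 1 to compound 3 (0.39 log units; beyond the scatter) together with a 2.6-fold lower number from compound 1 to compound 2 (0.41 log units; beyond the scatter) as the two steps beyond the scatter, so among these three compounds only the 2-methoxyphenyl group gives a number that differs from the rest. No accompanying measurement accounts for this difference.

From the compounds shown here alone, all three compounds carry a methoxyphenyl group on this carbonyl carbon, so it remains open how the number would respond to a quite different group there, such as an unsubstituted phenyl, a dimethylaminophenyl or a carboxylic acid on the phenyl ring. Going by these compounds, it is equally open whether a longer chain such as ethoxy in place of methoxy would keep the numbers of compound 2 and compound 3, and whether the same ranking of the three groups would hold on a different core.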